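This account rests on a few compounds, and the source may have more. Where it says the series, first, only, none or still open, it means among the compounds named here.

Compound 1 `COc1ccc(CNc2nc([Se]C)nc3ccccc23)cc1` gives 33000 nM in a functional assay on HTB-54 cells (Homo sapiens) for cytotoxicity, read by MTT assay, with a stated time of 72 h (on this read-out higher numbers stand for weaker inhibition of growth and lower numbers for stronger inhibition of growth), the second highest of the three numbers recorded. Compound 2 `CCCCC[Se]c1nc([Se]CCCCC)c2cccnc2n1` gives 15200 nM in this assay, and compound 3 `C[Se]c1nc(NCc2ccccc2)c2ccccc2n1` gives 74600 nM. Among the measured compounds shown here, the one single-point step recorded, a 2.3-fold higher number from compound 1 to compound 3 (0.35 log units; beyond the scatter), comes from a hydrogen in place of the methoxy group. Compound 4 `COc1ccc(CNc2nc(SC)nc3ccccc23)cc1` differs from compound 1 by a group of 2 heavy atoms (1 carbon, 1 sulfur; no ring) in place of a group of 2 heavy atoms (1 carbon, 1 selenium; no ring), on an aromatic carbon. For the measured compounds named here, no measured step touches this exchange of the chalcogen group on the shared core, and the step from compound 1 to compound 3 concerns a different part of the molecule, so no direction can be drawn from it. Compound 4 is therefore expected to stay close to compound 1, with no change at the digits printed from compound 1 to compound 4 (within the scatter) inside the scatter, at an estimated 33000 nM within 12000 nM to 90000 nM.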

Compound 4, concentration for 50% growth inhibition: 93700 nM
The estimate for compound 4 lay 2.8-fold (0.45 log units) below the measured number, and the stated range ends below it.
By their numbers in this assay, from the lowest: compound 2; then compound 1; then compounds 3 and 4 (each within the scatter of the next).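

The step at the aromatic carbon between two ring nitrogen atoms is a 2.8-fold higher number from compound 1 to compound 4 (0.45 log units; beyond the scatter) in this assay, so with methylsulfanyl entering, growth inhibition is weaker than with the selenium group. The earlier step concerned only the methoxy group, whereas this one shows that the chalcogen exchange itself moves the number beyond the scatter. Nothing available explains this difference. Still open, from the compounds shown here alone, is how an amine or a longer sulfur-bearing chain would read at this position, and whether the same exchange gives a similar step without the methoxy group.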